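The source may report more compounds than this note shows. Statements on the series, on what has been measured and on what is new or still open speak of the compounds shown alone.

Compound 1 `N#CC1=C(N)Oc2c(N)cc3nc4ccccc4nc3c2C12C(=O)N(Cc1cnnn1-c1cccc(Br)c1)c1ccccc12` gives 18900 nM in a functional assay on A549 cells (Homo sapiens) for antiproliferative activity, read by MTT assay, with a stated time of 48 h; on this read-out higher numbers stand for weaker inhibition and lower numbers for stronger inhibition. Compound 2 `COc1ccc(OC)c(-n2nncc2CN2C(=O)C3(C(C#N)=C(N)Oc4c(N)cc5nc6ccccc6nc5c43)c3ccccc32)c1` gives 28100 nM in this assay.

Among the measured compounds shown here, of the two numbers measured so far, that of compound 2 is the higher, but the step of a 1.5-fold higher number from compound 1 to compound 2 (0.17 log units; within the scatter) falls within the usual scatter of repeated measurements, so the two compounds are not told apart by this assay.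

Compound 3 `COc1cc(-n2nncc2CN2C(=O)C3(C(C#N)=C(N)Oc4c(N)cc5nc6ccccc6nc5c43)c3ccccc32)c(OC)cc1Cl` is the next compound, differing from compound 2 by chloro in place of hydrogen on an aromatic carbon. For the measured compounds named here, no measured step addresses a change of this kind: the only measured step, a 1.5-fold higher number from compound 1 to compound 2 (0.17 log units; within the scatter), exchanged the whole aryl group on the triazole nitrogen and produced no change beyond the scatter. Because a 1.5-fold higher number from compound 1 to compound 2 (0.17 log units; within the scatter) was flat, the expectation for adding a single chloro atom is a step of about a 1.0-fold lower number from compound 2 to compound 3 (0.02 log units; within the scatter), that is none beyond the scatter. Compound 3 is therefore estimated at 27000 nM, with a range from 10000 nM to 75000 nM.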

Compound 3, half-maximal inhibitory concentration: > 50000 nM
Compound 3 ended at the assay's limit; the forecaster's own chance of this, stated with the estimate: 5%; middle value at least 1.8-fold (0.26 log units) away from the limit.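

In this assay compound 3 gives > 50000 nM, which is a limit of the assay and not a number. Placing chloro on the aromatic carbon para to a large group gives an at least 1.7-fold higher number from compound 2 to compound 3 (0.25 log units; that floor lies within the scatter), so the floor of this step does not by itself separate the chloro compound from its parent. Among the compounds shown here, the aryl exchange gives the first step to pass the scatter, an at least 2.6-fold higher number from compound 1 to compound 3 (0.42 log units; beyond the scatter), showing that the group on the aromatic nitrogen can shift this read-out measurably, with 4-chloro-2,5-dimethoxyphenyl on the weaker side of 3-bromophenyl.

As far as these compounds go, the true size of the chloro step remains open, as only its floor can be read. The compounds shown also leave open how an amine or a carboxylic acid on that same aromatic carbon would read.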